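The compounds below may be only part of what the source reports. "The series", "measured", "known", "first", "only" and "open" are said of these compounds alone.

In an ADME assay on L02 cells (Homo sapiens) for cytotoxicity, read by MTT assay, with a stated time of 72 h (on this read-out higher numbers stand for weaker inhibition and lower numbers for stronger inhibition), compound 3 (`C=CC(=O)Nc1cccc(Oc2nc(Nc3ccc(OC)nc3)nc3c2CSCC3)c1`) gives > 50000 nM, which is a limit of the assay and not a number. Compound 1 (`C=CC(=O)Nc1cccc(Oc2nc(Nc3ccn(C)n3)nc3c2CSCC3)c1`) gives > 50000 nM, also a limit. Compound 2 (`CC(C)=CC(=O)Nc1cccc(Oc2nc(Nc3ccn(C)n3)nc3c2CSCC3)c1`) gives > 50000 nM, again a limit. All that is known so far is therefore (the limit of > 50000 nM in this assay, at which 3 of the 3 values shown sit).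

Compound 4 (`COc1ccc(Nc2nc3c(c(Oc4cccc(NC(=O)C=C(C)C)c4)n2)CSCC3)cn1`) differs from compound 3 in one place: 2-methylprop-1-en-1-yl in place of vinyl on a carbonyl carbon. The same swap, 2-methylprop-1-en-1-yl in place of vinyl on a carbonyl carbon, has been made once before, as a step that the two limits leave unreadable from compound 1 to compound 2. The other measured change, a step that the two limits leave unreadable from compound 1 to compound 3, lies elsewhere in the molecule. Neither gives a size to carry over, but all three compounds remain at the limit, including compound 2, which carries the new group, at > 50000 nM. No shift beyond the scatter is therefore expected in this assay, and no direction can be assigned. The estimated step is a step that the limit leaves unreadable from compound 3 to compound 4. Compound 4 is expected to lie near 60000 nM, within an estimated range of 30000 nM to 100000 nM, and will most likely be reported only as a limit.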

Compound 4, half-maximal inhibitory concentration: > 50000 nM
Compound 4 was reported as a limit; the forecaster's own chance of this, stated with the estimate: 90%; the middle value does not contradict the limit.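

Compound 4 sits at a limit, as do compound 2 and compound 3, so neither step into compound 4 can be read: the limit of > 50000 nM in this assay, at which 4 of the 4 values shown sit.

The compounds shown leave open how far past that limit each one lies, and so whether either swap changes the value at all.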